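A few compounds are considered here, and "the series" means these few. Any claim that something is new, unique, unknown or untested is made for them only; others in the source may bear on it.

Measured so far:
- compound 1, `CCOc1cc(NC(=O)C2(NC(=O)c3ccc4c(C5CCCC5)c(-c5ncc(Cl)cn5)n(C)c4c3)CCC2)ccc1/C=C/C(=O)OCOP(=O)(O)O`: 0.167 h
- compound 2, `CCOc1cc(NC(=O)C2(NC(=O)c3ccc4c(C5CCCC5)c(-c5ncc(Cl)cn5)n(C)c4c3)CCC2)ccc1/C=C/C(=O)OCc1ccccc1`: > 5 h
- compound 3, `CCOc1cc(NC(=O)C2(NC(=O)c3ccc4c(C5CCCC5)c(-c5ncc(Cl)cn5)n(C)c4c3)CCC2)ccc1/C=C/C(=O)OCCOCCOC`: 0.85 h

Three compounds sharing one core have been run in an ADME assay (liver) for pharmacokinetics, with Liver microsome (Homo sapiens) as the target, using microsomes; a higher number here means that the compound lasts longer, a lower number that the compound disappears faster. Compound 1 sits lowest of the two numbers shown; its nearest neighbour is compound 3, a gap of a 5.1-fold higher number from compound 1 to compound 3 (0.71 log units; beyond the scatter). For compound 2 the assay gives only a limit, (the limit of > 5 h in this assay, at which 1 of the 3 values shown sits), and not a number. Between compound 2 and compound 3 the change is an at least 5.8-fold lower number from compound 2 to compound 3 (0.76 log units; beyond the scatter).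

The unmeasured compound 4, `CCOc1cc(NC(=O)C2(NC(=O)c3ccc4c(C5CCCC5)c(-c5ncc(Cl)cn5)n(C)c4c3)CCC2)ccc1/C=C/C(=O)OCC(=O)OCc1ccc(Cl)cc1`, differs from compound 1 in one place: a group of 11 heavy atoms (8 carbon, 2 oxygen, 1 chlorine; one six-membered aromatic ring of carbon only) in place of a group of 5 heavy atoms (4 oxygen, 1 phosphorus; no ring), on a saturated chain carbon bound to an oxygen next to a carbonyl group. Going by the values given here, two measured steps bear on this. The exchange of the phosphorus-bearing group for a six-membered carbon ring gave an at least 29-fold higher number from compound 1 to compound 2 (1.47 log units; beyond the scatter), and its exchange for a chain of carbon and oxygen gave a 5.1-fold higher number from compound 1 to compound 3 (0.71 log units; beyond the scatter). Compound 4 carries both an aromatic ring and an additional carbonyl group, so an increase at least as large as the modest step is expected, and possibly one reaching the limit of the assay. The estimate for compound 4 is 3 h, between 0.9 h and 5 h, a step of an 18-fold higher number from compound 1 to compound 4 (1.25 log units; beyond the scatter).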

Compound 4, half-life: 5.62 h
The estimate for compound 4 lay 1.9-fold (0.27 log units) below the measured number; measured number outside the range, above it.
By their numbers in this assay, from the lowest: compound 1; then compound 3; then compound 4.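

In this assay, the ((4-chlorobenzyl)oxy)carbonyl group on this saturated chain carbon gives a 34-fold higher number from compound 1 to compound 4 (1.53 log units; beyond the scatter), so a group bearing an aromatic ring here now yields a readable number rather than only a limit. The same group also separates from the ring-free ether chain, with a 6.6-fold higher number from compound 3 to compound 4 (0.82 log units; beyond the scatter), and both ring-free groups, in compound 1 and compound 3, stay lower than compound 4. Compound 2 has only a limit, so its step to compound 4 cannot be read: the limit of > 5 h in this assay, at which 1 of the 4 values shown sits.

The compounds shown leave open which part of the ((4-chlorobenzyl)oxy)carbonyl group carries the step: the chlorine, the ring or the carbonyl. As far as these compounds go, whether a benzyloxycarbonyl group without chlorine, a carboxylic acid or an amine on this carbon would hold the number also stays open.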